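The source may hold more compounds than are shown below. What is called first, only, known or untested is meant among the compounds shown, and "the series" means these compounds.

Working notes on the series.

Compound 1 `ClCc1cccc(Cn2cnc3ncnc(Cl)c32)c1` and compound 2 `ClCc1ccccc1Cn1cnc2ncnc(Cl)c21` are built from the same atoms joined differently; the difference between the two cores is not broken down here. In a functional assay on IGROV-1 cells (Homo sapiens) for cytotoxicity, read by sulforhodamine B assay, with a stated time of 48 h (a lower number here means a stronger inhibitor of growth, a higher number a weaker inhibitor of growth), compound 1 gives 3380 nM, and compound 2 gives 4260 nM; these two numbers lie within the scatter of each other, so no order between them is claimed.

Compound 3 `ClCc1cccc(Cn2cnc3nc(Cl)nc(Cl)c32)c1` carries, relative to compound 1, the change (chloro in place of hydrogen on an aromatic carbon). In this assay compound 3 gives 17000 nM, which makes the step of a 5.0-fold higher number from compound 1 to compound 3 (0.70 log units; beyond the scatter).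

Compound 4 `ClCc1ccccc1Cn1cnc2nc(Cl)nc(Cl)c21` stands to compound 2 as compound 3 stands to compound 1: the change is chloro in place of hydrogen on an aromatic carbon, the same change in the same place, with the same surroundings in both pairs. Going by the values given here, only one measured instance of this change exists, so the expectation for compound 4 rests on that single step and on the value of compound 2.

For compound 4 in this assay the step is estimated at a 4.9-fold higher number from compound 2 to compound 4 (0.69 log units; beyond the scatter), taken to match the step from compound 1 to compound 3 because of a 5.0-fold higher number from compound 1 to compound 3 (0.70 log units; beyond the scatter). On that basis compound 4 is expected to give 21000 nM, with a range of 9000 nM to 50000 nM allowing for the scatter of the measurement and for the fact that the step is known from one pair only.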

Compound 4, concentration for 50% growth inhibition: 2880 nM
The estimate for compound 4 lay 7.3-fold (0.86 log units) above the measured number, outside the stated range (below it).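

In this assay, chloro in place of hydrogen on an aromatic carbon does not carry over from one core to the other, even though the surroundings of the change are the same in both pairs: the same change on two cores in this assay, a 5.0-fold higher number (0.70 log units; beyond the scatter) from compound 1 to compound 3 and a 1.5-fold lower number (0.17 log units; within the scatter) from compound 2 to compound 4, 7.4-fold (0.87 log units) apart, beyond the scatter of two such steps. On the core of compound 2 the change gives a 1.5-fold lower number from compound 2 to compound 4 (0.17 log units; within the scatter), so no order between these two compounds is claimed, and the weakening of growth inhibition seen on the core of compound 1 does not appear here. Going by these compounds alone, this shows that a step measured on one of these cores cannot simply be transferred to the other, but with only two pairs it does not show which outcome is more typical of the series, nor why the two cores differ.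

The compounds shown leave open whether an amine or a methoxy group on the same aromatic carbon, between two ring nitrogen atoms, would also give different steps on the two cores. They also leave open whether the gap between the cores would persist if a hydroxymethyl group stood in place of the chloromethyl group in both pairs.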